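Aryl urea series: chloro in place of methyl

A few compounds are considered here, and "the series" means these few. Any claim that something is new, unique, unknown or untested is made for them only; others in the source may bear on it.

Measured so far:
compound 1, `Cc1ccccc1NC(=O)N[C@H](C)c1ccccc1`: 99% in an ADME assay on the whole organism with Oryza sativa as the target, tested at 10 uM; on this read-out lower numbers stand for a stronger effect and higher numbers for a weaker effect at the one concentration tested
compound 2, `Cc1ccccc1NC(=O)N[C@@H](C)c1ccccc1`: 99%
compound 3, `C[C@H](NC(=O)Nc1cccc(F)c1)c1ccccc1`: 88%

Compound 1 stands level with compound 2 at the digits given, the two together the highest of the three numbers; compound 3 lies lower, beyond the scatter. Among the compounds with values here, the one step measured, no change at the digits printed from compound 1 to compound 2 (within the scatter), rests on the fact that compounds 1 and 2 differ only in the configuration as drawn and is the only comparison within the usual scatter.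

Compound 4, `C[C@@H](NC(=O)Nc1ccccc1Cl)c1ccccc1`, is the next member. It differs from compound 1 by chloro in place of methyl on an aromatic carbon. Within the data shown here, no measured step changes a ring substituent in this way: the step from compound 1 to compound 2 touches only the drawn configuration, and compound 3 carries a different substituent at a different place, so only its value can be set beside compound 1 without a computed step. That comparison shows a ring substituent change can move the number by a moderate amount, but nothing points in a direction for a chloro. The expected step of a number 7 percentage points lower from compound 1 to compound 4 (within the scatter) is therefore small, within or near the scatter. Compound 4 is estimated at 92%, between 78% and 100% in this assay.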

Compound 4, a percentage reported as activity, at one concentration (the size of the read-out at that concentration, not a potency): 93%
Compound 4: middle estimate off by 1 percentage points, on the low side; the measured number falls inside the stated range.
By their numbers in this assay, from the lowest: compounds 3, 4, 1 and 2 (each within the scatter of the next, the first and the last beyond it).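

At this place, on an aromatic carbon ortho to a large group, chloro in place of methyl gives a number 6 percentage points lower from compound 1 to compound 4 (within the scatter) in this assay, so this exchange leaves the read-out within the scatter. Within the data shown here, this is the first step that changes a ring substituent rather than only the drawn configuration, and it shows that methyl is not needed at this place to keep the number level with that of compound 1 at this one concentration. Nothing shown gives a reason for the size of this step.

As far as these compounds go, whether a methoxy, a trifluoromethyl or an amine at this place would move the number beyond the scatter stays open. Also open, from the compounds shown here alone, is whether the opposite drawn configuration of compound 4 would stay level with it, as compounds 1 and 2 do.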